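The source may report more compounds than this note shows. Statements on the series, on what has been measured and on what is new or still open speak of the compounds shown alone.

Measured so far:
- compound 1, `CCCCCCCCOc1nc(N)nc2c1ncn2/C=C1/CC1(CO)CO`: in an ADME assay on MOLT-3 cells (Homo sapiens) for cytotoxicity, with a stated time of 7 days (on this read-out lower numbers stand for higher toxicity in this test and higher numbers for lower toxicity in this test), compound 1 gives > 20000 nM, which is a limit of the test rather than a number.
- compound 2, `Nc1nc(NC2CC2)c2ncn(/C=C3/CC3(CO)CO)c2n1`: in this assay compound 2 gives > 20000 nM, likewise a limit.

Among the measured compounds shown here, compound 1 therefore stands at the edge of what this assay can read, and so does the only other value shown: the limit of > 20000 nM in this assay, at which 2 of the 2 values shown sit. For the measured compounds named here, the one measured change, from octyloxy to cyclopropylamino on an aromatic carbon, gives a step that the two limits leave unreadable from compound 1 to compound 2, so it yields no readable size or direction.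

Compound 3, `CCCSc1nc(N)nc2c1ncn2/C=C1/CC1(CO)CO`, differs from compound 1 by propylsulfanyl in place of octyloxy on an aromatic carbon. Going by the values given here, no measured step bears on this change in a readable way. With both shown values sitting at the limit, the step from compound 1 to compound 3 is expected to be a step that the limit leaves unreadable from compound 1 to compound 3, that is, nothing beyond the scatter. Compound 3 is therefore estimated to give 30000 nM in this assay, within a range from 12000 nM to 100000 nM, most likely reported again only as a limit.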

Compound 3, half-maximal cytotoxic concentration: > 20000 nM
Compound 3: a limit, no number; the forecaster's own chance of this, stated with the estimate: 80%; the middle value lies beyond the limit too.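

The steps linking compound 3 to compound 1 and compound 2 cannot be read, so they give neither a size nor a direction: the limit of > 20000 nM in this assay, at which 3 of the 3 values shown sit. From the compounds shown here alone, what stays open is whether octyloxy, cyclopropylamino and propylsulfanyl differ at all in this assay when no value shown is an actual number.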